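Para-halogen variation on the anilide of the shared core

A few compounds are considered here, and "the series" means these few. Any claim that something is new, unique, unknown or untested is made for them only; others in the source may bear on it.

Compound 1 `O=C(COc1ccc(/C=C2\SC(=O)NC2=O)cc1)Nc1ccc(F)cc1`: in a functional assay on PC-3 cells (Homo sapiens) for inhibition (on this read-out higher numbers stand for weaker inhibition of growth and lower numbers for stronger inhibition of growth), compound 1 gives > 100000 nM, which is a limit of the assay.
Compound 2 `O=C(COc1ccc(/C=C2\SC(=O)NC2=O)cc1)Nc1ccccc1`: in this assay compound 2 gives > 100000 nM, again a limit.
Compound 3 `O=C(COc1ccc(/C=C2\SC(=O)NC2=O)cc1)Nc1ccc(Cl)cc1`: in this assay compound 3 gives 83400 nM.

Within the data shown here, compound 3 is the only member of the series with a number in this assay; the other two values sit at the limit of > 100000 nM in this assay, at which 2 of the 3 values shown sit. The step that the two limits leave unreadable from compound 1 to compound 2 is therefore not readable. The steps of an at least 1.1-fold lower number from compound 1 to compound 3 (0.07 log units; that floor lies within the scatter) and an at least 1.1-fold lower number from compound 2 to compound 3 (0.07 log units; that floor lies within the scatter) show floors that lie within the scatter, so the halogen swaps at this position have not yet produced a readable change.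

Compound 4 `O=C(COc1ccc(/C=C2\SC(=O)NC2=O)cc1)Nc1ccc(Br)cc1` differs from compound 3 by bromo in place of chloro on an aromatic carbon. Both steps bearing on this position are small, so no change beyond the scatter is expected for a 1.3-fold lower number from compound 3 to compound 4 (0.11 log units; within the scatter). Compound 4 is estimated at 65000 nM in this assay, with a range from 25000 nM to 100000 nM, and a real chance that only a limit is reported.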

Compound 4, concentration for 50% growth inhibition: 86600 nM
Compound 4: the middle estimate sits 1.3-fold (0.12 log units) below what was measured; measured number inside the range.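

In this assay, among these compounds, the change from 4-chlorophenyl to 4-bromophenyl gives the first step at this position with a number at both ends: a 1.0-fold higher number from compound 3 to compound 4 (0.02 log units; within the scatter). Bromo also gives only floors within the scatter against the other two groups, with an at least 1.1-fold lower number from compound 2 to compound 4 (0.06 log units; that floor lies within the scatter) and an at least 1.1-fold lower number from compound 1 to compound 4 (0.06 log units; that floor lies within the scatter), so no halogen effect can be read from these steps. Compound 1 and compound 2 remain tied to a limit, which keeps the lower end of the comparison open: the limit of > 100000 nM in this assay, at which 2 of the 4 values shown sit.

Going by these compounds, it remains open whether any group at this position can move the value beyond the scatter, for example an amine, a carboxylic acid or a methoxy group in place of the halogen. On these data alone, whether a longer chain in the linker of the shared core would change the picture also remains open.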